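Cyclic Amine Replaces an Open Chain on the Sulfonyl Group

The compounds below may be only part of what the source reports. "The series", "measured", "known", "first", "only" and "open" are said of these compounds alone.

Measured compounds:
Compound 1 `COCCNS(=O)(=O)c1ccc(C)c(C#Cc2cc(Cl)ccc2OCC(=O)O)c1`: 3.6 nM
Compound 2 `CCCS(=O)(=O)c1ccc(C)c(C#Cc2cc(Cl)ccc2OC(CC)C(=O)O)c1`: 30 nM

In an assay on CHO cells for displacement of a labelled ligand from prostaglandin D2 receptor 2 (Homo sapiens), read by scintillation counting (on this read-out lower numbers stand for stronger inhibition and higher numbers for weaker inhibition), compound 1 gives 3.6 nM, the lowest of the two numbers. Going by the values given here, compound 2 gives 30 nM, a gap well beyond the scatter, though these two structures differ in more than one place and so support no single step.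

Compound 3 `Cc1ccc(S(=O)(=O)N2CCCCC2C)cc1C#Cc1cc(Cl)ccc1OCC(=O)O` has not yet been measured. It differs from compound 1 in one place: 2-methylpiperidin-1-yl in place of (2-methoxyethyl)amino on a sulfonyl sulfur. Among the compounds with values here, no measured pair shows a change of this kind, so the expectation rests on compound 1 alone. A small weakening is expected, a 2.2-fold higher number from compound 1 to compound 3 (0.35 log units; beyond the scatter), at most a little beyond the scatter. Compound 3 is estimated at 8 nM, with a range from 2 nM to 30 nM.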

Compound 3, inhibition constant: 1.9 nM
For compound 3 the middle estimate is 4.2-fold (0.62 log units) above the measured one, and the stated range ends above it.
By their numbers in this assay, from the lowest: compounds 3 and 1 (each within the scatter of the next); then compound 2.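

At the sulfonyl sulfur, the open (2-methoxyethyl)amino chain can be exchanged for the 2-methylpiperidin-1-yl ring in this assay with a 1.9-fold lower number from compound 1 to compound 3 (0.28 log units; within the scatter) as the result. The hydrogen-bond donor and acceptor of the departing chain are therefore not required here for a low number, since the entering ring has neither. Nothing available explains why the two groups read alike.

On these data alone, whether the ring's methyl matters remains open, as does whether unsubstituted piperidin-1-yl or morpholin-4-yl would read the same at this sulfur.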